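The compounds below may be only part of what the source reports. "The series", "measured", "known", "first", "only" and "open" are said of these compounds alone.

Working notes on the series in a functional assay on MIA PaCa-2 cells (Homo sapiens) for inhibition, read by MTT assay, with a stated time of 3 days; on this read-out lower numbers stand for stronger inhibition and higher numbers for weaker inhibition. Compound 1 `CCN(CC)S(=O)(=O)c1ccc(S(=O)(=O)N2CCC[C@@H](C(=O)N[C@@H]3CCN(C(=O)OC(C)(C)C)C3)C2)cc1` returns only a limit in this assay: compound 1 gives > 10000 nM. Compound 2 `CCOC(=O)[C@H]1CCN(S(=O)(=O)c2ccc(S(=O)(=O)N(CC)CC)cc2)C1` is likewise reported only as a limit in this assay, where compound 2 gives > 10000 nM. Compound 3 `CCOC(=O)[C@@H]1CCCN(S(=O)(=O)c2ccc(S(=O)(=O)N(CC)CC)cc2C)C1` also sits at a limit in this assay, where compound 3 gives > 10000 nM. Compound 1 therefore stands nowhere apart from the others: every value shown is the limit of > 10000 nM in this assay, at which 3 of the 3 values shown sit, and no number separates any two of the measured compounds. Among the measured compounds shown here, no step between measured compounds can be read from the data.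

Compound 4 `CCN(CC)S(=O)(=O)c1ccc(S(=O)(=O)N2CCC[C@@H](C(=O)NC)C2)cc1` differs from compound 1 by methyl in place of 1-(tert-butoxycarbonyl)pyrrolidin-3-yl on an amide-type nitrogen. With all measured values at the limit of > 10000 nM in this assay, at which 3 of the 3 values shown sit, the data give no direction for this change, and the step that the limit leaves unreadable from compound 1 to compound 4 is expected to be none beyond the scatter. Compound 4 is expected to give 20000 nM in this assay, with a range from 5000 nM to 80000 nM, most probably reported again only as a limit.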

Compound 4, half-maximal inhibitory concentration: > 10000 nM
Compound 4: only a limit was reported; the forecaster's own chance of this, stated with the estimate: 85%; the middle value does not contradict the limit.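

In this assay, among the compounds shown here, compound 1 and compound 4 both sit at a limit, so no step between them can be read: the limit of > 10000 nM in this assay, at which 4 of the 4 values shown sit. The compounds shown leave open which change to the shared core, if any, would bring a measurable value in this assay within reach.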